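Replacing the Aryl Amide Group of Compound 2

The compounds below may be only part of what the source reports. "The series", "measured", "known", "first", "only" and "open" are said of these compounds alone.

- compound 1 `C=C(CC)C(=O)c1ccc(OCC(=O)NCCCN2CCCC2=O)c(Cl)c1Cl`: 13800 nM
- compound 2 `C=C(CC)C(=O)c1ccc(OCC(=O)Nc2ccc(O)c(Cl)c2)c(Cl)c1Cl`: 5500 nM

Both compounds were tested in a functional assay on CLL cells (Homo sapiens) for cytotoxicity, read by MTT assay, with a stated time of 48 h; a lower number here means that less compound is needed, a higher number that more compound is needed for the effect. Of the two, compound 2 has the lower number, at 5500 nM, and the gap to compound 1 lies beyond the usual scatter. The next structure, compound 3 `C=C(CC)C(=O)c1ccc(OCC(=O)NCCO)c(Cl)c1Cl`, keeps the shared core and changes only the amide substituent: 2-hydroxyethyl in place of 3-chloro-4-hydroxyphenyl on an amide-type nitrogen. In words, 2-hydroxyethyl stands in place of 3-chloro-4-hydroxyphenyl on an amide-type nitrogen.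

Going by the values given here, only one measured step bears on this change. It is a 2.5-fold lower number from compound 1 to compound 2 (0.40 log units; beyond the scatter), a modest step that brought in the same 3-chloro-4-hydroxyphenyl in place of 3-(2-oxopyrrolidin-1-yl)propyl. Compound 3 loses that group again, so a move back towards compound 1 in this assay is expected, to a higher number of similar size. This rests on a single step, and the 2-hydroxyethyl group itself has not been measured on this core. The expected change is a 2.2-fold higher number from compound 2 to compound 3 (0.34 log units; beyond the scatter). For compound 3 the estimated value is 12000 nM, with an expected range from 5000 nM to 30000 nM.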

Compound 3, half-maximal effective concentration: > 25000 nM
Compound 3 was reported as a limit; the forecaster's own chance of this, stated with the estimate: 10%; at least 2.0-fold (0.31 log units) between middle value and limit.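

Moving from the 3-chloro-4-hydroxyphenyl group to 2-hydroxyethyl on the amide-type nitrogen gives an at least 4.5-fold higher number from compound 2 to compound 3 (0.65 log units; beyond the scatter), a larger step than the one that first separated compound 1 and compound 2. This leaves compound 2 with the lowest number of the three in this assay, and its steps to both compounds without an aromatic ring on the amide substituent lie beyond the scatter. The comparison with the other non-aromatic substituent is less firm, at an at least 1.8-fold higher number from compound 1 to compound 3 (0.25 log units; that floor lies within the scatter), so the order of those two compounds stays unsettled, and the reading for compound 3 is a limit and not a number, so how far it lies from either neighbour remains unknown: the limit of > 25000 nM in this assay, at which 1 of the 3 values shown sits.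

What the compounds shown leave open is which part of the 3-chloro-4-hydroxyphenyl group goes with the lower number, since the aromatic ring, the chlorine and the hydroxy group enter and leave together; a plain phenyl or a 4-hydroxyphenyl group would separate them. Equally open, from the compounds shown here alone, is whether a chain ending in an amine or a carboxylic acid would behave like the 2-hydroxyethyl group on this nitrogen.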